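Trading a dichlorobenzyl amine for a methylated benzyl amine

The compounds below may be only part of what the source reports. "The series", "measured", "known", "first", "only" and "open" are said of these compounds alone.

Measured compounds:
- Compound 1, `O=S(=O)(NCCCNCc1ccccc1Cl)c1cc(C(F)(F)F)cc(C(F)(F)F)c1`: 10000 nM
- Compound 2, `O=S(=O)(NCCCCNCc1ccc(Br)cc1)c1cc(C(F)(F)F)cc(C(F)(F)F)c1`: 2000 nM
- Compound 3, `O=S(=O)(NCCCNCc1ccc(Cl)c(Cl)c1)c1cc(C(F)(F)F)cc(C(F)(F)F)c1`: 2500 nM

All three share a bis(trifluoromethyl)phenyl sulfonamide core joined through a short saturated chain to a benzylic amine, and all were tested in a functional assay on HPAC cells (Homo sapiens) for inhibition, read by MTT assay, with a stated time of 72 h; on this read-out lower numbers stand for stronger inhibition of growth and higher numbers for weaker inhibition of growth. Compound 3 gives 2500 nM, the second highest of the three numbers; compound 2 sits close by, within the scatter, while compound 1 is clearly weaker, as a 4.0-fold lower number from compound 1 to compound 3 (0.60 log units; beyond the scatter) shows. Among the compounds with values here, the move from compound 1 to compound 2, a 5.0-fold lower number from compound 1 to compound 2 (0.70 log units; beyond the scatter), points the same way: the halogenated benzyl groups of compound 2 and compound 3 beat the single ortho-chlorine pattern of compound 1, and a 1.3-fold higher number from compound 2 to compound 3 (0.10 log units; within the scatter) is a step within the scatter.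

Compound 4, `CN(CCCNS(=O)(=O)c1cc(C(F)(F)F)cc(C(F)(F)F)c1)Cc1ccccc1`, is not yet measured. Relative to compound 3 the change is benzyl(methyl)amino in place of (3,4-dichlorobenzyl)amino on a saturated chain carbon, three bonds along the chain from a sulfonamide nitrogen. Within the data shown here, no measured step covers the loss of both chlorines together with the methylation of the amine nitrogen, so the expectation rests loosely on the halogen-bearing compounds being stronger. A weaker result is expected for compound 4, roughly a 2.4-fold higher number from compound 3 to compound 4 (0.38 log units; beyond the scatter), with an estimate of 6000 nM and a range from 2500 nM to 15000 nM.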

Compound 4, concentration for 50% growth inhibition: 30000 nM
Compound 4: the middle estimate sits 5.0-fold (0.70 log units) below what was measured; the whole stated range lies below it.
By their numbers in this assay, from the lowest: compounds 2 and 3 (each within the scatter of the next); then compound 1; then compound 4.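

In this assay, within the data shown here, this change, on a saturated chain carbon three bonds along the chain from a sulfonamide nitrogen, has a far larger effect than any step among the earlier compounds: there is a 12-fold higher number from compound 3 to compound 4 (1.08 log units; beyond the scatter) and a 15-fold higher number from compound 2 to compound 4 (1.18 log units; beyond the scatter), and even the 2-chlorobenzyl compound gives way, with a 3.0-fold higher number from compound 1 to compound 4 (0.48 log units; beyond the scatter). Compound 4 is therefore the weakest of the four, and its benzyl(methyl)amino group has no halogen and 0 hydrogen-bond donors, whereas the (3,4-dichlorobenzyl)amino group it replaces has 1. Nothing available explains this drop.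

The compounds shown leave open whether the loss of the chlorines or the methyl on the amine nitrogen accounts for the drop, since both changes arrive together. A plain benzylamino group and a (3,4-dichlorobenzyl)(methyl)amino group at this place would separate the two.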